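Compound 2 to compound 4: a longer side chain

The source may hold more compounds than are shown below. What is called first, only, known or untested is meant among the compounds shown, and "the series" means these compounds.

Measured so far in a functional assay on MDA-MB-231 cells (Homo sapiens) for inhibition, read by MTT assay, with a stated time of 72 h; on this read-out lower numbers stand for stronger inhibition and higher numbers for weaker inhibition
Compound 1 `CC(C)[C@H](NC(=O)c1cc(Cl)ccc1OCCCCN)C(=O)Nc1ccc([N+](=O)[O-])cc1Cl` at 5590 nM
Compound 2 `C[C@H](NC(=O)c1cc(Cl)ccc1OCCNC(=O)OC(C)(C)C)C(=O)Nc1ccc([N+](=O)[O-])cc1Cl` at > 10000 nM (a limit)
Compound 3 `C[C@H](NC(=O)c1cc(Cl)ccc1OCCN)C(=O)Nc1ccc([N+](=O)[O-])cc1Cl` at > 10000 nM (a limit)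

Compound 2 gives only a limit (> 10000 nM) and no number. From the compounds shown here alone, that places it at the limit of > 10000 nM in this assay, at which 2 of the 3 values shown sit, and its exact potency stays unknown. For the measured compounds named here, the change to compound 4 `CC(C)(C)OC(=O)CC[C@H](NC(=O)c1cc(Cl)ccc1OCCNC(=O)OC(C)(C)C)C(=O)Nc1ccc([N+](=O)[O-])cc1Cl` is (tert-butoxycarbonyl)methyl in place of hydrogen on a saturated chain carbon, two bonds along the chain from an amide-type nitrogen and a carbonyl carbon and it has no direct precedent here. Going by the values given here, the only measured step that bears on it is a step that the two limits leave unreadable from compound 2 to compound 3 and it offers no size to carry over. Among the compounds with values here, compound 1 gives a number (5590 nM) but no measured step links it to compound 2. The expected step in this assay is therefore a number no higher from compound 2 to compound 4 (the limit leaves the size open) with no direction that the numbers support. Another limit is the likeliest report for compound 4. Compound 4 is estimated at 10000 nM with an expected range from 4000 nM to 20000 nM and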

Compound 4, half-maximal inhibitory concentration: > 10000 nM
Compound 4: no number, only a limit (the forecaster's own chance of this, stated with the estimate: 70%); the middle value lies on the limit itself.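

Compound 2 and compound 4 both give only a limit and no number, so no step between them can be read: the limit of > 10000 nM in this assay, at which 3 of the 4 values shown sit.

The compounds shown leave open whether the (tert-butoxycarbonyl)methyl group changes inhibition at all, and by how much.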